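Working notes: benzoyl to carbamoyl in the series

This account rests on a few compounds, and the source may have more. Where it says the series, first, only, none or still open, it means among the compounds named here.

Compound 1 `COc1ccc([C@@H]2C/C(=N/OCc3cn(-c4ccc(C(=O)c5ccccc5)cc4)nn3)c3cc(CC=C(C)C)c(OC)cc3O2)cc1`: 41%
Compound 2 `COc1cc2c(cc1CC=C(C)C)/C(=N/O)C[C@@H](c1ccc(O)cc1)O2`: 93%

Both values come from a functional assay on MCF7 cells (Homo sapiens) for inhibition, read by sulforhodamine B assay, with a stated time of 48 h, tested at 50 uM; a higher number here means more inhibition of growth at the concentration tested, a lower number less inhibition of growth. Compound 1 stands lowest of the two, and the gap up to compound 2 lies beyond the scatter. Within the data shown here, no pair of measured compounds differs in one place only, so no measured step guides the next change.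

Compound 3 `COc1ccc([C@@H]2C/C(=N/OCc3cn(-c4ccc(C(N)=O)cc4)nn3)c3cc(CC=C(C)C)c(OC)cc3O2)cc1` keeps the core of compound 1 but has amino in place of phenyl on a carbonyl carbon, benzoyl to carbamoyl (amino in place of phenyl on a carbonyl carbon). In this assay, a small rise that does not clearly exceed the scatter is expected, though the direction is uncertain. The expected change is a number 7 percentage points higher from compound 1 to compound 3 (within the scatter). The wide range reflects the lack of a matched comparison, with compound 2 at 93% showing only how far the read-out can reach. For compound 3 the estimated value is 48%, with an expected range of 25% to 75%.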

Compound 3, percent growth inhibition at one concentration: 100%
The estimate for compound 3 lay 52 percentage points below the measured number; measured number above the stated range.
By their numbers in this assay, from the lowest: compound 1; then compounds 2 and 3 (each within the scatter of the next).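

In this assay, among these compounds, the change to amino in place of phenyl on a carbonyl carbon provides the first matched step: a number 59 percentage points higher from compound 1 to compound 3 (beyond the scatter). This place is therefore sensitive to the group on the carbonyl carbon, since benzoyl to carbamoyl alone, with the rest of compound 1 kept, moves the read-out well beyond the scatter. No available evidence bears on what lies behind this step.

From the compounds shown here alone, a single step cannot separate the departure of the phenyl from the arrival of the amino, so methylamino, methyl or hydroxyl on the same carbonyl carbon, the last giving a carboxylic acid, remain open comparisons. A read-out at one concentration also leaves open how compound 3 behaves at lower concentrations.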